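Benzyloxycarbonyl in place of bromo: notes on compound 4

The compounds below may be only part of what the source reports. "The series", "measured", "known", "first", "only" and "open" are said of these compounds alone.

In a functional assay on A549 cells (Homo sapiens) for antiproliferative activity, read by MTT assay, with a stated time of 48 h (on this read-out higher numbers stand for weaker inhibition and lower numbers for stronger inhibition), compound 3 (`COc1ccc(-c2nn(-c3ccccc3)cc2-c2nc3cc(Br)ccc3[nH]2)cc1`) gives 6370 nM. Compound 2 (`O=C(OCc1ccccc1)c1ccc2[nH]c(-c3cn(-c4ccccc4)nc3-c3ccc(Cl)cc3)nc2c1`) gives 7730 nM, level with compound 3 within the scatter. Compound 1 (`O=C(OCc1ccccc1)c1ccc2[nH]c(-c3cn(-c4ccccc4)nc3-c3ccc(F)cc3)nc2c1`) gives a higher number, 21500 nM.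

The next structure is compound 4 (`COc1ccc(-c2nn(-c3ccccc3)cc2-c2nc3cc(C(=O)OCc4ccccc4)ccc3[nH]2)cc1`), with benzyloxycarbonyl in place of bromo on an aromatic carbon.

Within the data shown here, no measured step covers this change. The only one available, a 2.8-fold lower number from compound 1 to compound 2 (0.44 log units; beyond the scatter), is modest and is a different change, chloro in place of fluoro on an aromatic carbon. It bears only indirectly, as compound 1 and compound 2 already carry benzyloxycarbonyl. Their values, 21500 nM for compound 1 and 7730 nM for compound 2, suggest a number for compound 4 near or somewhat above that of compound 3, with no step beyond the scatter expected in this assay.

The expected change is a 1.4-fold higher number from compound 3 to compound 4 (0.15 log units; within the scatter). For compound 4 the estimate is 9000 nM, with an expected range from 3500 nM to 22000 nM.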

Compound 4, half-maximal inhibitory concentration: 11900 nM
For compound 4 the middle estimate is 1.3-fold (0.12 log units) below the measured one, within the range that was stated.
By their numbers in this assay, from the lowest: compounds 3, 2, 4 and 1 (each within the scatter of the next, the first and the last beyond it).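

Working from the bromo compound, a 1.9-fold higher number from compound 3 to compound 4 (0.27 log units; within the scatter) gives the first direct reading of this change in this assay and shows that benzyloxycarbonyl and bromo on this aromatic carbon cannot be told apart, even though the entering group is much larger and brings its own aromatic ring. With benzyloxycarbonyl held fixed, methoxy in place of chloro gives a 1.5-fold higher number from compound 2 to compound 4 (0.19 log units; within the scatter) and methoxy in place of fluoro gives a 1.8-fold lower number from compound 1 to compound 4 (0.26 log units; within the scatter), so methoxy cannot be separated from either halogen here. No measurement available here accounts for these steps.

On these data alone, whether a carboxylic acid, an amide or a methyl ester on this aromatic carbon would read differently remains open. As far as these compounds go, it is also open whether bromo and benzyloxycarbonyl would stay level with chloro or fluoro in place of methoxy.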